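The source may report more compounds than this note shows. Statements on the series, on what has been measured and on what is new or still open speak of the compounds shown alone.

Measured in a functional assay on DU-145 cells (Homo sapiens) for antiproliferative activity, read by MTT assay, with a stated time of 72 h; a lower number here means a stronger inhibitor, a higher number a weaker inhibitor:
Compound 1 `COc1cc2c(Nc3ccc(C#N)cc3)ncnc2cc1OCCCN1CCCC1` gives 14400 nM.
Compound 2 `COc1cc2c(Nc3ccc(C#N)cc3)ncnc2cc1OCCCN1CCC(O)CC1` gives 74900 nM.
Compound 3 `COc1cc2c(Nc3ccc(C#N)cc3)ncnc2cc1OCCCN1CCN(C)CC1` gives 46500 nM.

Compound 2 gives the highest number of the three. One gap is a 5.2-fold higher number from compound 1 to compound 2 (0.72 log units; beyond the scatter), which is beyond the scatter, whereas the other gap is a 1.6-fold lower number from compound 2 to compound 3 (0.21 log units; within the scatter), which is within it, so compound 2 and compound 3 cannot be ordered against each other.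

Compound 4 `CCN1CCN(CCCOc2cc3ncnc(Nc4ccc(C#N)cc4)c3cc2OC)CC1` is the compound to be measured. Relative to compound 2 it differs by 4-ethylpiperazin-1-yl in place of 4-hydroxypiperidin-1-yl on a saturated chain carbon, three bonds along the chain from an oxygen on an aromatic ring.

Within the data shown here, the one measured step that speaks to this change is the one from compound 2 to compound 3, where a 4-methylpiperazin-1-yl replaced the 4-hydroxypiperidin-1-yl at the same place and gave a 1.6-fold lower number from compound 2 to compound 3 (0.21 log units; within the scatter), a step within the scatter. Compound 4 carries a 4-ethylpiperazin-1-yl at that place, which differs from the group in compound 3 only by the ethyl in place of the methyl, so no step beyond the scatter is expected in this assay, and the number is expected to land near that of compound 3, below compound 2 by a small margin.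

Compound 4 is therefore expected to give about 42000 nM, in a range from 18000 nM to 95000 nM. That estimate corresponds to a step of a 1.8-fold lower number from compound 2 to compound 4 (0.25 log units; within the scatter).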

Compound 4, half-maximal inhibitory concentration: 34400 nM
Estimate against measurement, compound 4: 1.2-fold (0.09 log units) above; the measured number falls inside the stated range.
By their numbers in this assay, from the lowest: compound 1; then compounds 4, 3 and 2 (each within the scatter of the next, the first and the last beyond it).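

In this assay, the 4-ethylpiperazin-1-yl group gives the first separation from the 4-hydroxypiperidin-1-yl group at this place on the chain, with a 2.2-fold lower number from compound 2 to compound 4 (0.34 log units; beyond the scatter), whereas the 4-methylpiperazin-1-yl group had stayed within the scatter of it. Ethyl in place of methyl on the piperazine ring does not separate the two piperazine compounds, at a 1.4-fold lower number from compound 3 to compound 4 (0.13 log units; within the scatter), and the pyrrolidin-1-yl group keeps the lowest number, with a 2.4-fold higher number from compound 1 to compound 4 (0.38 log units; beyond the scatter), so all three six-membered ring groups shown now stand beyond the scatter of compound 1. Nothing measured here accounts for any of these steps.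

Going by these compounds, it remains open whether a 4-propylpiperazin-1-yl or 4-benzylpiperazin-1-yl group would stay with compound 3 and compound 4, and whether a morpholin-4-yl, piperidin-1-yl or dimethylamino group would fall nearer to compound 1. Also open, on these data alone, is how these amines behave on a shorter or longer chain than the propyl chain shared by all four compounds, and whether the order holds when the nitrile on the shared core is replaced by a halogen.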